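The compounds below may be only part of what the source reports. "The series", "measured", "known", "first", "only" and "open" are said of these compounds alone.

Measured so far in a functional assay on HT-1080 cells (Homo sapiens) for cytotoxicity, read by MTT assay, with a stated time of 72 h; on this read-out lower numbers stand for stronger inhibition and higher numbers for weaker inhibition:
- compound 1 `COc1cccc(/C=C2\CCC/C(=C\c3cccc(Br)c3)C2=O)c1OC`: 12200 nM
- compound 2 `COc1ccc(/C=C2\CCC/C(=C\c3cccc(OC)c3OC)C2=O)cc1`: 16300 nM

Among the measured compounds shown here, compound 2 carries the higher of the two numbers, but it cannot be separated from compound 1, since the only measured step, a 1.3-fold higher number from compound 1 to compound 2 (0.13 log units; within the scatter), exchanges 3-bromophenyl for 4-methoxyphenyl and stays within the scatter.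

The next compound is compound 3 `COc1cccc(/C=C2\CCC/C(=C\c3cccc(O)c3)C2=O)c1OC`. It has 3-hydroxyphenyl in place of 4-methoxyphenyl on a double-bonded chain carbon bound to a double-bonded ring carbon. For the measured compounds named here, the same place is involved in the measured step, so that step is the only evidence that bears on this change. It shows one exchange at this place with no effect beyond the scatter. Going by the values given here, no measured compound carries a hydroxyl group, so the data give no direct reading of this group, and the range has to stay wide.

In this assay, no shift beyond the scatter is expected, with the estimate being a 1.4-fold lower number from compound 2 to compound 3 (0.13 log units; within the scatter). For compound 3 the expected value is 12000 nM, with an estimated range of 5000 nM to 28000 nM.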

Compound 3, half-maximal inhibitory concentration: 8500 nM
For compound 3 the middle estimate is 1.4-fold (0.15 log units) above the measured one, within the range that was stated.
By their numbers in this assay, from the lowest: compounds 3, 1 and 2 (each within the scatter of the next).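

Compound 3 is the only one of the three with a hydrogen-bond donor at this place, on a double-bonded chain carbon bound to a double-bonded ring carbon. In this assay, 3-hydroxyphenyl in place of 4-methoxyphenyl gives a 1.9-fold lower number from compound 2 to compound 3 (0.28 log units; within the scatter), and hydroxy in place of bromo on an aromatic carbon gives a 1.4-fold lower number from compound 1 to compound 3 (0.16 log units; within the scatter), so adding this donor produces no separable shift against either earlier group. With both steps inside the scatter, the three groups at this place now form a single cluster of numbers, and no measurement available here offers any explanation for the small differences among them.

Still open, going by these compounds, is whether any group at this place can move the number beyond the scatter, for instance an amine or a carboxylic acid on the aromatic ring, or a longer chain in place of the hydroxy group. The compounds shown also leave open how much the group shared by all three, on the other side of the core, contributes to these numbers.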